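Trading a Carboxypropyl Chain for an Amino Group

The source may report more compounds than this note shows. Statements on the series, on what has been measured and on what is new or still open speak of the compounds shown alone.

Compound 1 `CCOc1ccccc1-c1ccc(-c2nc3cnccc3c(C[C@H](C)C(=O)O)c2C#N)cc1` sits at the lower end of the two numbers recorded in a physicochemical assay for lipophilicity, read by HPLC, at pH 7.5; on this read-out lower numbers stand for lower lipophilicity and higher numbers for higher lipophilicity: compound 1 gives 2.2, while compound 2 `CC[C@@H](Nc1c(C#N)c(-c2ccc(-c3ccccc3C(F)(F)F)cc2)nc2cnccc12)C(N)=O` gives 3.1, a gap beyond the usual scatter of this assay. Compound 3 `CCOc1ccccc1-c1ccc(-c2nc3cnccc3c(N)c2C#N)cc1` has not yet been measured in this assay. It differs from compound 1 in a single place: amino in place of 2-carboxypropyl on an aromatic carbon. Among the measured compounds shown here, with no measured step of this kind to lean on, an upward step is expected, namely a number 1.40 log units higher from compound 1 to compound 3 (beyond the scatter). Compound 3 is accordingly estimated at 3.6, with a range from 2.9 to 4.3.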

Compound 3, distribution coefficient: 3
Compound 3: middle estimate off by 0.60 log units, on the high side; the measured number falls inside the stated range.
By their numbers in this assay, from the lowest: compound 1; then compounds 3 and 2 (each within the scatter of the next).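

Replacing 2-carboxypropyl with amino on this aromatic carbon, ortho to a cyano group, gives a number 0.80 log units higher from compound 1 to compound 3 (beyond the scatter) in this assay. So this position does register the change, and in this pair a group of 6 heavy atoms gives way to a single nitrogen while the number goes up. Nothing measured here gives a reason for this rise. On these data alone, it remains open whether the step follows the loss of the chain or the arrival of the nitrogen. A propyl chain or a methylamino group on the same carbon would help to separate the two.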